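The source may report more compounds than this note shows. Statements on the series, on what has been measured and on what is new or still open speak of the compounds shown alone.

In an in vitro functional assay on HEK293S cells with Glucose-dependent insulinotropic receptor (Homo sapiens) as the target, read by HTRF and cAMP accumulation, with a stated time of 45 min (on this read-out lower numbers stand for smaller maximal responses and higher numbers for larger maximal responses), compound 1 `CC(C)(C)OC(=O)N1CCN(c2ccc(OCc3ccc(S(C)(=O)=O)cc3)nn2)CC1` gives 28%, compound 2 `C[C@@H]1CN(c2ncc(OCc3ccc(S(C)(=O)=O)cc3)cn2)CCN1C(=O)OC(C)(C)C` gives 106% and compound 3 `C[C@H]1CN(c2ncc(OCc3ccc(S(C)(=O)=O)cc3)cn2)CCN1C(=O)OC(C)(C)C` gives 163%. Compound 2 thus stands second highest of the three, with compound 3 above it and compound 1 below. Going by the values given here, the only measured step between compounds differing in a single place is a number 57 percentage points higher from compound 2 to compound 3 (beyond the scatter), a large shift that rests on (the fact that compounds 2 and 3 differ only in the configuration as drawn). Compound 4 `C[C@@H]1CN(c2ncc(OCc3ccc(S(C)(=O)=O)cc3)cn2)[C@@H](C)CN1C(=O)OC(C)(C)C` differs from compound 2 by methyl in place of hydrogen on a saturated ring carbon. Among the compounds with values here, no measured step adds a methyl, so the direction is uncertain; the step from compound 2 to compound 3 shows only that the arrangement at this ring can move the response far. For compound 4 the estimated step is a number 6 percentage points lower from compound 2 to compound 4 (within the scatter). Compound 4 is therefore expected to give 100%, within 40% to 165%.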

Compound 4, intrinsic activity: the largest response reached, in percent of the reference agonist's in the Glucose-dependent insulinotropic receptor assay: 152%
The estimate for compound 4 lay 52 percentage points below the measured number; low and high end bracket the measured number.
By their numbers in the Glucose-dependent insulinotropic receptor assay, from the lowest: compound 1; then compound 2; then compound 4; then compound 3.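

In the Glucose-dependent insulinotropic receptor assay, one added methyl on a saturated ring carbon, next to the ring nitrogen, gives a number 46 percentage points higher from compound 2 to compound 4 (beyond the scatter), so a change of substituent on this ring can move the response strongly, not only a change of configuration. In a physicochemical assay for lipophilicity, using the shake flask method, in phosphate buffer, measured as octanol-water partition, at pH 7.4 (on this read-out lower numbers stand for lower lipophilicity and higher numbers for higher lipophilicity), compound 2 gives > 3.7, which is a limit of the assay and not a number. In the physicochemical assay, compound 4 gives > 3.7, again a limit, so the step between the two cannot be read.

On these data alone, what an ethyl group or an amine on this ring carbon would do to the maximal response stays open. So does the effect of the opposite configuration at the carbon bearing the new methyl.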